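From 2-chlorophenyl to 3-chlorophenyl: a small step expected

The source may hold more compounds than are shown below. What is called first, only, known or untested is meant among the compounds shown, and "the series" means these compounds.

In a functional assay on cells (Homo sapiens) for cytotoxicity, read by MTT assay, with a stated time of 24 h (a higher number here means a weaker inhibitor, a lower number a stronger inhibitor), compound 1 `CCCCCCCCCCCCCCNC(=O)[C@H](CO)/N=C/c1ccccc1[N+](=O)[O-]` gives 21700 nM, compound 2 `CCCCCCCCCCCCCCNC(=O)[C@H](CO)/N=C/c1ccccc1Cl` gives 10300 nM and compound 3 `CCCCCCCCCCCCCCNC(=O)[C@H](CO)/N=C/c1ccc(O)cc1` gives 19300 nM. Among the measured compounds shown here, compound 2 stands clear of only one of its two neighbours: the data show a 2.1-fold lower number from compound 1 to compound 2 (0.32 log units; beyond the scatter), whereas the remaining comparison gives a 1.9-fold higher number from compound 2 to compound 3 (0.27 log units; within the scatter). The third step in the set is a 1.1-fold lower number from compound 1 to compound 3 (0.05 log units; within the scatter).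

Compound 4 `CCCCCCCCCCCCCCNC(=O)[C@H](CO)/N=C/c1cccc(Cl)c1` has not yet been measured. It differs from compound 2 as follows: 3-chlorophenyl in place of 2-chlorophenyl on a carbon with a double bond to nitrogen, with 3-chlorophenyl in place of 2-chlorophenyl on a carbon with a double bond to nitrogen. For the measured compounds named here, no measured step moves the chlorine, so the evidence is indirect. Even exchanging one group for another produced only a modest change, the largest being a 2.1-fold lower number from compound 1 to compound 2 (0.32 log units; beyond the scatter). A step in this assay no larger than the scatter, in either direction, is therefore expected. The expected step is a 1.2-fold higher number from compound 2 to compound 4 (0.07 log units; within the scatter). For compound 4 the estimated value is 12000 nM, with an expected range of 6500 nM to 22000 nM.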

Compound 4, half-maximal inhibitory concentration: 24100 nM
Beside the measured number, compound 4's estimate is 2.0-fold (0.30 log units) below it; measured number above the stated range.
By their numbers in this assay, from the lowest: compounds 2, 3, 1 and 4 (each within the scatter of the next, the first and the last beyond it).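

Moving the chlorine, with the same atoms on the same carbon, is enough to register in this assay: the data show a 2.3-fold higher number from compound 2 to compound 4 (0.37 log units; beyond the scatter) and so a modest but real dependence on where the chlorine sits. That separation belongs to the 2-chlorophenyl group alone among the two chlorinated compounds, since the 3-chlorophenyl group does not stand apart from the other two, with a 1.2-fold higher number from compound 3 to compound 4 (0.10 log units; within the scatter) and a 1.1-fold higher number from compound 1 to compound 4 (0.05 log units; within the scatter) both within the scatter. Nothing available here accounts for this dependence on the position of the chlorine.

The compounds shown leave open whether a bromine atom or a methoxy group on the ring would show the same dependence on position. They also leave open whether the step would survive a shorter chain in place of the long one.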